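Nitrofuran chalcones: butyl in place of methylsulfanyl

A few compounds are considered here, and "the series" means these few. Any claim that something is new, unique, unknown or untested is made for them only; others in the source may bear on it.

Working notes on a small chalcone set. Compound 1 `CC(C)(C)c1ccc(C(=O)/C=C/c2ccco2)cc1` and compound 2 `O=C(/C=C/c1cccc([N+](=O)[O-])c1)c1ccc(N2CCCCC2)cc1` belong to the series but carry no number here: in an ADME assay on Vero cells (Chlorocebus sabaeus) for cytotoxicity, read by resazurin assay, with a stated time of 72 h (on this read-out higher numbers stand for lower toxicity in this test and lower numbers for higher toxicity in this test), compound 1 is entered as "not determined" (no result reported), and compound 2 likewise as "not determined" (no result reported). Among the compounds with values here, compound 3 `CSc1ccc(C(=O)/C=C/c2ccc([N+](=O)[O-])o2)cc1` is therefore the only member with a measured half-maximal cytotoxic concentration; in this assay compound 3 gives 40700 nM, and with the other two entries lacking any number, compound 3 stands alone as the sole reference point and no steps between measured compounds can be stated.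

Compound 4 `CCCCc1ccc(C(=O)/C=C/c2ccc([N+](=O)[O-])o2)cc1` is the next entry to be run. It differs from compound 3 in one place: butyl in place of methylsulfanyl on an aromatic carbon. Nothing in the measured set shows how an exchange of this kind moves the half-maximal cytotoxic concentration in this assay, so no direction can be read from the data; the working expectation is a step of at most modest size, not clearly beyond the scatter, and if anything towards somewhat higher toxicity in this test.

On that basis the estimated shift a 1.4-fold lower number from compound 3 to compound 4 (0.13 log units; within the scatter) is taken as small. Compound 4 is expected to give about 30000 nM in this assay, with a range from 12000 nM to 80000 nM.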

Compound 4, half-maximal cytotoxic concentration: 75700 nM
Compound 4: middle estimate off by 2.5-fold (0.40 log units), on the low side; the range from low to high includes it.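

In this assay, butyl in place of methylsulfanyl on an aromatic carbon, para to a large group, gives a 1.9-fold higher number from compound 3 to compound 4 (0.27 log units; within the scatter), so the two compounds cannot be told apart in this test. Within the data shown here, this is the only step available, and it shows that at this position, methylsulfanyl with its sulfur and its hydrogen-bond acceptor can give way to the all-carbon butyl chain without a shift beyond the usual scatter. No supporting data bear on why the result falls as it does.

As far as these compounds go, a single step within the scatter does not set the limits of this position: it remains open whether a primary amine, a carboxylic acid or a longer chain such as octyl in the same place would move the half-maximal cytotoxic concentration beyond the scatter. From the compounds shown here alone, it also remains open whether the same exchange would behave alike on another core, such as that of compound 1 or compound 2, as neither compound has a number to anchor a comparison.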